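This account rests on a few compounds, and the source may have more. Where it says the series, first, only, none or still open, it means among the compounds named here.

In a functional assay on GC3/MTK- cells (Homo sapiens) for inhibition (on this read-out higher numbers stand for weaker inhibition and lower numbers for stronger inhibition), compound 1 `C#CCN(Cc1ccc2nc(C)nc(O)c2c1)c1ccc(C#N)cc1` gives 5000 nM while compound 2 `C#CCN(Cc1ccc2nc(C)nc(O)c2c1)c1ccc([N+](=O)[O-])cc1` gives 4800 nM and compound 3 `C#CCN(Cc1ccc2nc(C)nc(O)c2c1)c1ccc(C(=O)c2ccccc2)cc1` gives 6200 nM in the same test. Compound 3 thus stands level with the other two: the steps of a 1.2-fold higher number from compound 1 to compound 3 (0.09 log units; within the scatter) and a 1.3-fold higher number from compound 2 to compound 3 (0.11 log units; within the scatter) stay within the scatter, as does a 1.0-fold lower number from compound 1 to compound 2 (0.02 log units; within the scatter) at the same place. Compound 4 `C#CCN(Cc1ccc2nc(C)nc(O)c2c1)c1ccc(S(N)(=O)=O)cc1` carries sulfamoyl in place of benzoyl on an aromatic carbon at that place. Sulfamoyl itself is untested, yet all three swaps there left the number flat. So in this assay the expected step of a 1.1-fold lower number from compound 3 to compound 4 (0.05 log units; within the scatter) is none beyond the scatter. For compound 4 the estimated value is 5500 nM with an expected range from 2000 nM to 15000 nM as a working guess.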

Compound 4, half-maximal inhibitory concentration: > 26000 nM
Compound 4: a limit, no number; the forecaster's own chance of this, stated with the estimate: 10%; at least 4.7-fold (0.67 log units) between middle value and limit.
By their numbers in this assay, from the lowest: compounds 2, 1 and 3 (each within the scatter of the next). At a limit, above all of these: compound 4.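

The value for compound 4 in this assay is a limit, not a number: the limit of > 26000 nM in this assay, at which 1 of the 4 values shown sits. The position is thus not indifferent to every group: cyano, nitro and benzoyl stood level, but sulfamoyl gives an at least 4.1-fold higher number from compound 3 to compound 4 (0.62 log units; beyond the scatter), an at least 5.4-fold higher number from compound 2 to compound 4 (0.73 log units; beyond the scatter) and an at least 5.2-fold higher number from compound 1 to compound 4 (0.71 log units; beyond the scatter). Unlike benzoyl, sulfamoyl carries a hydrogen-bond donor, though these data cannot link that donor to the step.

On these data alone, how far the number truly rises stays open behind the limit. Also open, as far as these compounds go, is how an amine or a carboxylic acid at this place would read out, and whether either would stand with sulfamoyl or with the other three groups.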